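The source may report more compounds than this note shows. Statements on the series, on what has been measured and on what is new or still open speak of the compounds shown alone.

Measured so far in a functional assay on DU-145 cells (Homo sapiens) for inhibition, read by trypan blue exclusion, with a stated time of 96 h; a lower number here means a stronger inhibitor of growth, a higher number a weaker inhibitor of growth:
compound 1 `O=C(/C(=C\c1ccccc1OCc1ccccc1)SCc1ccc(F)cc1)c1ccc(Cl)cc1`, 1000 nM
compound 2 `O=C(/C(=C\c1ccc(O)cc1)SCc1ccc(F)cc1)c1ccc(Cl)cc1`, 25000 nM
compound 3 `COc1ccccc1/C=C(/SCc1ccc(F)cc1)C(=O)c1ccc(Cl)cc1`, 10000 nM

Compound 1 gives the lowest number of the three. The nearest to it is compound 3, reached by a 10-fold higher number from compound 1 to compound 3 (1.00 log units; beyond the scatter); compound 2 lies further off, and the step of a 2.5-fold lower number from compound 2 to compound 3 (0.40 log units; beyond the scatter) places compound 3 between the two. Both of these measured steps alter the group on the double-bonded chain carbon bound to a double-bonded chain carbon, and in all three compounds the (4-fluorobenzyl)sulfanyl group and the 4-chlorophenyl carbonyl are kept unchanged.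

Compound 4 `O=C(/C(=C\c1ccccc1OCc1ccccc1)S(=O)(=O)c1ccc(F)cc1)c1ccc(Cl)cc1` is the next compound in the series. It differs from compound 1 at a single place: (4-fluorophenyl)sulfonyl in place of (4-fluorobenzyl)sulfanyl on a double-bonded chain carbon bound to a carbonyl carbon and a double-bonded chain carbon. Within the data shown here, no measured step touches this group, so the two steps above offer no direct guide to its size or direction; they only show that this core tolerates changes of modest size elsewhere without the number leaving the low-micromolar range. The change here is larger in kind than either measured step, so a step beyond the scatter in either direction is plausible, and the expectation is set with a wide range.

For compound 4 the expected step is a 3.0-fold higher number from compound 1 to compound 4 (0.48 log units; beyond the scatter), giving an estimate of 3000 nM with a range from 400 nM to 25000 nM in this assay.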

Compound 4, concentration for 50% growth inhibition: 1000 nM
Compound 4: middle estimate off by 3.0-fold (0.48 log units), on the high side; the range from low to high includes it.
By their numbers in this assay, from the lowest: compounds 1 and 4 (each within the scatter of the next); then compound 3; then compound 2.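

In this assay, among these compounds, (4-fluorophenyl)sulfonyl in place of (4-fluorobenzyl)sulfanyl on the double-bonded chain carbon bound to a carbonyl carbon and a double-bonded chain carbon gives no change at the digits printed from compound 1 to compound 4 (within the scatter), the first reading at this place. On the background of compound 1, this place therefore accepts an exchange of the sulfanyl group for a sulfonyl group, with the entering group carrying 2 hydrogen-bond acceptors against 1 in the group it replaces, and the growth-inhibition number stays within the scatter. Nothing measured on the compounds at hand accounts for this result, and this single pair does not establish a wider tolerance at this place.

Two things alter together in this step, the sulfur-linked group and the chain carbon that the leaving group holds, so a (4-fluorophenyl)sulfanyl or a (4-fluorobenzyl)sulfonyl group would be needed to read them apart. Also open, going by these compounds, are whether the same exchange holds on the background of compound 2 or compound 3, and how an amine or a carboxylic acid would read at this place.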